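Methoxy to Ethoxy: an Expected Shift in Lipophilicity

The source may report more compounds than this note shows. Statements on the series, on what has been measured and on what is new or still open speak of the compounds shown alone.

Compound 1 `CC(C)OC[C@H](Oc1ncnc2c1cnn2-c1ncccc1Cl)C(=O)Nc1ccc(Cl)cn1` gives 3.5 in a physicochemical assay for lipophilicity; on this read-out lower numbers stand for lower lipophilicity and higher numbers for higher lipophilicity. Compound 2 `CCOC[C@H](Oc1ncnc2c1cnn2-c1ncccc1Cl)C(=O)Nc1ccc(Cl)cn1` gives 3 in this assay. The two differ by methyl in place of hydrogen on a saturated chain carbon bound to an oxygen on a saturated carbon and a saturated chain carbon, and that step is a number 0.50 log units higher from compound 2 to compound 1 (beyond the scatter). Compound 3 `COC[C@H](Oc1ncnc2c1cnn2-c1ncccc1Cl)C(=O)Nc1cnc(C)cn1` gives 1.4 in this assay; the difference between its core and the core of compound 2 is not broken down here. Compound 4 `CCOC[C@H](Oc1ncnc2c1cnn2-c1ncccc1Cl)C(=O)Nc1cnc(C)cn1` has not yet been measured. It differs from compound 3 by methyl in place of hydrogen on a saturated chain carbon bound to an oxygen on a saturated carbon. This is the same kind of change as that between compound 2 and compound 1, though not the same: there the carbon is bound to an oxygen on a saturated carbon and a saturated chain carbon, here only to an oxygen on a saturated carbon. Resting on the earlier step of a number 0.50 log units higher from compound 2 to compound 1 (beyond the scatter), the step from compound 3 to compound 4 is expected to be a number 0.50 log units higher from compound 3 to compound 4 (beyond the scatter). Compound 4 is therefore estimated at 1.9, between 1.5 and 2.3.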

Compound 4, distribution coefficient: 1.8
The estimate for compound 4 lay 0.10 log units above the measured number, and the stated range covers the measured number.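

In this assay, adding a methyl raises the number on both cores, with a step of a number 0.50 log units higher from compound 2 to compound 1 (beyond the scatter) and another a number 0.40 log units higher from compound 3 to compound 4 (beyond the scatter), so the direction carried over in these two pairs, although the methyl sits on a differently substituted carbon in each. Swapping the amide-nitrogen group instead, 5-methylpyrazin-2-yl in place of 5-chloropyridin-2-yl, gives a large step of a number 1.20 log units lower from compound 2 to compound 4 (beyond the scatter), which shows that the core sets much of the value. Two pairs cannot establish a general rule for the series, and nothing shown here explains the shifts.

From the compounds shown here alone, what remains open is how a longer chain, such as propoxy, would behave at this place. Going by these compounds, an amine on the same chain is equally open.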